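The compounds below may be only part of what the source reports. "The series", "measured", "known", "first", "only" and "open" are said of these compounds alone.

Among the measured compounds shown here, compound 1 `COc1ccc([C@@H]2CC(=O)c3c(O)cc(OCc4cn(Cc5ccc(F)cc5)nn4)cc3O2)cc1O` is one of three compounds measured in a functional assay on RAW264.7 cells (Mus musculus) for inhibition, read by Griess assay, with stated times of 2 h and 24 h; a higher number here means a weaker inhibitor, a lower number a stronger inhibitor. In this assay compound 1 gives 15100 nM, the second highest of the three numbers. Compound 2 `COc1ccc([C@@H]2C/C(=N\O)c3c(O)cc(OCc4cn(-c5ccccc5)nn4)cc3O2)cc1O` gives 6130 nM, and compound 3 `COc1ccc([C@@H]2C/C(=N\O)c3c(O)cc(OCc4cn(Cc5ccccc5C)nn4)cc3O2)cc1O` gives 18000 nM; compound 2 and compound 3 share a core built differently from that of compound 1, and the number for compound 3 sits within the scatter of the number for compound 1. For the measured compounds named here, the only single-point step measured, a 2.9-fold higher number from compound 2 to compound 3 (0.47 log units; beyond the scatter), shows that a 2-methylbenzyl on an aromatic nitrogen gave a modestly weaker inhibitor than a phenyl there.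

Compound 4 `COc1ccc([C@@H]2CC(=O)c3c(O)cc(OCc4cn(Cc5ccccc5C)nn4)cc3O2)cc1O` is not yet measured. It differs from compound 1 at one place: 2-methylphenyl in place of 4-fluorophenyl on a saturated chain carbon bound to an aromatic nitrogen. Going by the values given here, no measured pair compares a 4-fluorobenzyl with a 2-methylbenzyl directly, and the step from compound 2 to compound 3 starts from phenyl, not from a benzyl group, so it bears on this change only loosely. Compound 1 and compound 3 differ both at this group and in the core, yet their numbers sit within the scatter of each other, which hints that the change matters little. Compound 4 is therefore expected to give a number close to that of compound 1, with a 1.2-fold higher number from compound 1 to compound 4 (0.08 log units; within the scatter) amounting to no step beyond the scatter. The estimate for compound 4 is 18000 nM, within a range from 8000 nM to 40000 nM.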

Compound 4, half-maximal inhibitory concentration: 13100 nM
Estimate against measurement, compound 4: 1.4-fold (0.14 log units) above, and the stated range covers the measured number.
By their numbers in this assay, from the lowest: compound 2; then compounds 4, 1 and 3 (each within the scatter of the next).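

In this assay, replacing the 4-fluorobenzyl with a 2-methylbenzyl gives a 1.2-fold lower number from compound 1 to compound 4 (0.06 log units; within the scatter), so on the core of compound 1 the two groups cannot be told apart at this position. The earlier compounds shown here could only hint at this, as compound 1 and compound 3 differ in both this group and the core, whereas here the core stays the same and the change is confined to the group on the saturated chain carbon bound to an aromatic nitrogen. No measurement available here explains why the two groups give such similar numbers.

This single pair does not show whether the position would accept more different groups, such as a benzyl carrying an amine or a carboxylic acid, or a longer chain between the phenyl ring and the aromatic nitrogen. It also leaves open whether the step seen on the other core, a 2.9-fold higher number from compound 2 to compound 3 (0.47 log units; beyond the scatter), would recur on the core of compound 1, where a phenyl bound directly to the aromatic nitrogen does not appear among the compounds shown.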